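Working notes: 4-methylpiperazin-1-yl on compound 3

A few compounds are considered here, and "the series" means these few. Any claim that something is new, unique, unknown or untested is made for them only; others in the source may bear on it.

Measured so far in a physicochemical assay for solubility, at pH 7.4; on this read-out higher numbers stand for higher solubility and lower numbers for lower solubility
- compound 1 `CN1CCN(c2ccccc2C(=O)/C=C/c2ccc(/C=C/C(=O)NO)cc2)CC1` gives 210000 nM
- compound 2 `O=C(/C=C/c1cccc(/C=C/C(=O)c2ccccc2)c1)NO` gives 12000 nM
- compound 3 `O=C(/C=C/c1cccc(/C=C/C(=O)c2ccccc2)n1)NO` gives 16000 nM

Compound 3 (16000 nM) lies within the scatter of compound 2 (12000 nM). Compound 1 (210000 nM) stands higher than compound 3, beyond the scatter.

The next compound is compound 4 `CN1CCN(c2ccccc2C(=O)/C=C/c2cccc(/C=C/C(=O)NO)n2)CC1`. It differs from compound 3 by 4-methylpiperazin-1-yl in place of hydrogen on an aromatic carbon, ortho to a large group (4-methylpiperazin-1-yl in place of hydrogen on an aromatic carbon).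

Going by the values given here, no measured pair isolates this change. Among the compounds with values here, compound 1 is the only measured compound that carries 4-methylpiperazin-1-yl, and it also differs from compound 3 elsewhere in the structure, so the comparison is indirect. Even so, the gap between compound 1 (210000 nM) and compound 3 (16000 nM) is the only guide available. On that basis, a rise beyond the scatter is expected in this assay, probably somewhat smaller than that gap. The estimated step is upward (an 8.1-fold higher number from compound 3 to compound 4 (0.91 log units; beyond the scatter)). Compound 4 is estimated at 130000 nM (expected range 50000 nM to 300000 nM).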

Compound 4, solubility: 450000 nM
Compound 4: middle estimate off by 3.5-fold (0.54 log units), on the low side; the whole stated range lies below it.
By their numbers in this assay, from the lowest: compounds 2 and 3 (each within the scatter of the next); then compound 1; then compound 4.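

In this assay, going by these compounds alone, 4-methylpiperazin-1-yl in place of hydrogen on an aromatic carbon, ortho to a large group, brings a 28-fold higher number from compound 3 to compound 4 (1.45 log units; beyond the scatter), and this pair is the first to isolate the change. Until now the group appeared only in compound 1, which also differs from compound 3 elsewhere in the structure, so no reading could be tied to this group at this position; on the core of compound 3, the change now carries a large upward step. Nothing measured among these compounds accounts for the size of the step.

The compounds shown do not separate the contribution of the ring from that of its methyl, as they include no piperazin-1-yl, morpholin-4-yl or dimethylamino group at this position, and no carboxylic acid there either. Also open, on these data alone, is whether a step of this size would recur with 4-methylpiperazin-1-yl elsewhere on the same ring or on another core, such as that of compound 2, as this single pair gives one reading at one position.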